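Benzyl ester to free acid on a shared purine-bearing scaffold

The source may hold more compounds than are shown below. What is called first, only, known or untested is meant among the compounds shown, and "the series" means these compounds.

Of the compounds shown here, two have been measured in a functional assay on the whole organism (Tail, strain ICR) with Mus musculus as the target, in the tail flick test, with a stated time of 150 min, at a dose of 25 umol/kg by the oral route; a higher number here means a stronger effect of the compound at the dose given, a lower number a weaker effect. Compound 1, `O=C(O)CC[C@H](NC(=O)CN(c1nc(Cl)nc2[nH]cnc12)C1CC1)C(=O)O`, gives 29.5%. Compound 2, `CSCC[C@H](NC(=O)CN(c1nc(Cl)nc2[nH]cnc12)C1CC1)C(=O)OCc1ccccc1`, gives 17.6%, the lower of the two numbers; compound 1 stands higher by a margin that goes beyond the usual scatter. The two differ in more than one place, so their values are simply compared, with no single change to credit for the gap.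

The next compound, compound 3, `CSCC[C@H](NC(=O)CN(c1nc(Cl)nc2[nH]cnc12)C1CC1)C(=O)O`, keeps the side chain of compound 2 and alters only the ester end. The change is hydrogen in place of benzyl on an oxygen next to a carbonyl group. Put one bond further out, benzyloxycarbonyl becomes carboxy.

Going by the values given here, no pair of measured compounds differs in this one place alone, so the size of this step is not known from the data. Compound 1, which also carries a free carboxy end, sits above compound 2, and on that basis a rise beyond the scatter is expected for a number 9.4 percentage points higher from compound 2 to compound 3 (within the scatter). Compound 3 is therefore estimated at 27%, with a range from 12% to 45%.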

Compound 3, a percentage reported as activity, at one dose (the size of the read-out at that dose, not a potency): 4.14%
Beside the measured number, compound 3's estimate is 22.9 percentage points above it; the measured number lies below the stated range.
By their numbers in this assay, from the lowest: compound 3; then compound 2; then compound 1.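

Taking the benzyl off the ester end does not raise the number in this assay: benzyloxycarbonyl to carboxy on the methylsulfanyl side chain lowers it (a number 13.5 percentage points lower from compound 2 to compound 3 (beyond the scatter)), so at this position the benzyl ester goes with more effect at the dose given than the free carboxy end. A free carboxy end alone therefore does not bring a high number, and the side chain counts as well: with that end the same in both compounds, methylsulfanyl in place of carboxy on the saturated chain carbon also brings the number down (a number 25.4 percentage points lower from compound 1 to compound 3 (beyond the scatter)). No other kind of measurement bears on these two steps.

On these data alone, it remains open how the benzyl ester would read on the side chain of compound 1, and whether a smaller ester such as a methyl ester would sit nearer to compound 2 or to compound 3. An amine at the end of the side chain, or a longer chain ending in a carboxylic acid, would show how far the high number of compound 1 depends on the carboxy group at exactly that place.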